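Exchanging a Ring Substituent on the Shared Core

The source may hold more compounds than are shown below. What is called first, only, known or untested is meant among the compounds shown, and "the series" means these compounds.

Of the compounds shown here, three with the same core have been measured. In a physicochemical assay for lipophilicity, at pH 7.4 (a higher number here means a more lipophilic compound, a lower number a more polar compound), compound 3 `C[C@@H]1CN(c2ccc(OCc3ccccc3)c(C(=O)Nc3ccnnc3)c2)C[C@H](C)O1` gives 5.4, the second highest of the three. Compound 2 `O=C(Nc1ccnnc1)c1cc(N2CCCC2)ccc1OCc1ccccc1` gives 6.1, the highest of the three, and compound 1 `CN1CCC(c2ccc(OCc3ccccc3)c(C(=O)Nc3ccnnc3)c2)CC1` gives 2.3, the lowest.

The next structure, compound 4 `O=C(Nc1ccnnc1)c1cc(N2CCC(CO)CC2)ccc1OCc1ccccc1`, keeps the same atoms but joins them differently: 4-(hydroxymethyl)piperidin-1-yl in place of 2,6-dimethylmorpholin-4-yl on an aromatic carbon. In words, 4-(hydroxymethyl)piperidin-1-yl takes the place of 2,6-dimethylmorpholin-4-yl, para to a benzyloxy group.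

The closest guide is the modest step of a number 0.70 log units lower from compound 2 to compound 3 (beyond the scatter), which also exchanges one of these ring groups for another at this place. The large steps of a number 3.80 log units higher from compound 1 to compound 2 (beyond the scatter) and a number 3.10 log units higher from compound 1 to compound 3 (beyond the scatter) bear less on the question, since both start from 1-methylpiperidin-4-yl, a group that plays no part in this change. Among the measured compounds shown here, no measured compound carries the entering group, so the direction rests on the structural change alone, and the size is taken from the modest step.

A modest fall is therefore expected, a number 0.70 log units lower from compound 3 to compound 4 (beyond the scatter). For compound 4 the estimated value is 4.7, with an expected range of 4 to 5.4.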

Compound 4, distribution coefficient: 3.5
For compound 4 the middle estimate is 1.20 log units above the measured one, outside the stated range (below it).
By their numbers in this assay, from the lowest: compound 1; then compound 4; then compound 3; then compound 2.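

At this place, para to a benzyloxy group, two ring groups built from the same atoms turn out to be far from interchangeable in this assay: the new exchange gives a number 1.90 log units lower from compound 3 to compound 4 (beyond the scatter) and is large, whereas the earlier exchange of pyrrolidin-1-yl for 2,6-dimethylmorpholin-4-yl gave a number 0.70 log units lower from compound 2 to compound 3 (beyond the scatter) and was modest. The change from a ring with 2 hetero atoms and 0 hydrogen-bond donors to a ring with 1 hetero atom and 1 hydrogen-bond donor therefore comes with a much bigger shift than heavy-atom count alone would suggest, since that count stays the same. Compound 4 also opens the middle of the range, with a number 2.60 log units lower from compound 2 to compound 4 (beyond the scatter) on one side and a number 1.20 log units higher from compound 1 to compound 4 (beyond the scatter) on the other, so the ring groups at this place now cover the span without a wide empty gap. Nothing in the information available accounts for the size of these steps.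

Whether the hydroxymethyl group itself carries the shift remains open, as a comparison with 4-(methoxymethyl)piperidin-1-yl or plain piperidin-1-yl at this place lies outside the compounds shown. From the compounds shown here alone, how an amine or a carboxylic acid on the same piperidine ring would compare is equally open.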